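Two bromines on the pyridine: an expected further loss

The compounds below may be only part of what the source reports. "The series", "measured", "known", "first", "only" and "open" are said of these compounds alone.

Compound 1 `O=S(=O)(CSc1nnc(Br)n1Cc1ccc(Br)c2ccccc12)Nc1cccnc1` gives 32 nM in an assay on HEK293 cells for inhibition of solute carrier family 22 member 12 (Homo sapiens); on this read-out lower numbers stand for stronger inhibition and higher numbers for weaker inhibition. Compound 2 `O=S(=O)(CSc1nnc(Br)n1Cc1ccc(Br)c2ccccc12)Nc1ccc(Cl)nc1` gives 1940 nM in this assay. Compound 3 `O=S(=O)(CSc1nnc(Br)n1Cc1ccc(Br)c2ccccc12)Nc1cccnc1Cl` gives 5100 nM in this assay.

Among these three, compound 3 gives the highest number, with compound 2 nearest and compound 1 furthest. Compound 4 `O=S(=O)(CSc1nnc(Br)n1Cc1ccc(Br)c2ccccc12)Nc1ccc(Br)nc1Br` differs from compound 3 by 2,6-dibromopyridin-3-yl in place of 2-chloropyridin-3-yl on a sulfonamide nitrogen. Among the compounds with values here, two measured steps bear on this change: a 61-fold higher number from compound 1 to compound 2 (1.78 log units; beyond the scatter) and a 160-fold higher number from compound 1 to compound 3 (2.20 log units; beyond the scatter), each a halogen entering the pyridine ring; the smaller step is a 2.6-fold higher number from compound 2 to compound 3 (0.42 log units; beyond the scatter). Compound 4 carries halogen at both positions at once, so a further rise in this assay is expected for compound 4, estimated as a 2.4-fold higher number from compound 3 to compound 4 (0.37 log units; beyond the scatter). Compound 4 is therefore estimated at 12000 nM, in a range from 3000 nM to 50000 nM.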

Compound 4, half-maximal inhibitory concentration: 5410 nM
Compound 4: middle estimate off by 2.2-fold (0.35 log units), on the high side, and the stated range covers the measured number.
By their numbers in this assay, from the lowest: compound 1; then compound 2; then compounds 3 and 4 (each within the scatter of the next).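

In this assay, 2,6-dibromopyridin-3-yl on the sulfonamide nitrogen cannot be told from 2-chloropyridin-3-yl, at a 1.1-fold higher number from compound 3 to compound 4 (0.03 log units; within the scatter). The same group still reads a 2.8-fold higher number from compound 2 to compound 4 (0.45 log units; beyond the scatter) against 6-chloropyridin-3-yl and a 170-fold higher number from compound 1 to compound 4 (2.23 log units; beyond the scatter) against pyridin-3-yl. Among these compounds, then, the large loss seen with a single halogen in compound 3 does not grow measurably when the pyridine carries two. Whether an amine or a methyl group on the pyridine would cost as much remains open, and no measurement on hand says why the second halogen adds no visible loss.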